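A few compounds are considered here, and "the series" means these few. Any claim that something is new, unique, unknown or untested is made for them only; others in the source may bear on it.

Values so far in a functional assay on HCT-15 cells (Homo sapiens) for cytotoxicity, read by ELISA, with a stated time of 2 days (on this read-out lower numbers stand for stronger inhibition and higher numbers for weaker inhibition), are as follows.

compound 1 `Oc1cccc(-c2cc(-c3ccccc3)cc(-c3ccco3)n2)c1` gives 13500 nM
compound 2 `Oc1cccc(-c2cc(-c3ccccc3)cc(-c3cccc(O)c3)n2)c1` gives 18400 nM
compound 3 `Oc1ccc(-c2cc(-c3ccccc3)cc(-c3ccccc3)n2)cc1` gives 3700 nM

Compound 3 holds the lowest number of the three, beyond the scatter against both others. Compound 4 `Oc1ccc(-c2cc(-c3ccccc3)cc(-c3ccc(O)cc3)n2)cc1` differs from it by hydroxy in place of hydrogen on an aromatic carbon with hydroxy in place of hydrogen on an aromatic carbon, phenyl to 4-hydroxyphenyl. Within the data shown here, the one measured step, a 1.4-fold higher number from compound 1 to compound 2 (0.13 log units; within the scatter) for 3-hydroxyphenyl in place of furan-2-yl, is a different exchange and gives only weak guidance. Compound 2 at 18400 nM also carries a further hydroxy group and has a higher number than compound 3. A moderate rise in this assay is therefore expected. The estimated step is a 2.0-fold higher number from compound 3 to compound 4 (0.31 log units; beyond the scatter) on this limited evidence. For compound 4 the estimated value is 7500 nM within an expected range from 2500 nM to 22000 nM in this series.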

Compound 4, half-maximal inhibitory concentration: 3000 nM
Compound 4: middle estimate off by 2.5-fold (0.40 log units), on the high side; the measured number falls inside the stated range.
By their numbers in this assay, from the lowest: compounds 4 and 3 (each within the scatter of the next); then compounds 1 and 2 (each within the scatter of the next).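

In this assay hydroxy in place of hydrogen on an aromatic carbon, para to a large group, gives a step within the scatter (a 1.2-fold lower number from compound 3 to compound 4 (0.09 log units; within the scatter)). Phenyl to 4-hydroxyphenyl at this position therefore has no measurable cost here, which the earlier compounds, differing by other exchanges, could not show. No measured evidence on a cause accompanies this result.

Going by these compounds, whether an amine, a methoxy group or a carboxylic acid at this position would read the same stays open. So does the effect of hydroxy on the remaining phenyl group of compound 4.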